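The source may report more compounds than this note shows. Statements on the series, on what has been measured and on what is new or still open speak of the compounds shown alone.

In a functional assay on ZR-75-1 cells (Homo sapiens) for cytotoxicity, read by MTT assay, with a stated time of 72 h (on this read-out higher numbers stand for an effect only at larger amounts of compound and lower numbers for an effect already at smaller amounts), compound 1 (`CCOC(=O)c1c(C)coc1-c1ccc2c(CC)cccc2c1OC`) gives 3.9 ug/mL. Compound 2 (`CCc1cccc2c(OC)c(-c3occ(C)c3C(=O)NC)ccc12`) gives > 10 ug/mL, which is a limit of the assay. Compound 3 (`CCc1cccc2c(OC)c(-c3occ(C)c3COC)ccc12`) gives 9.7 ug/mL, the higher of the two true numbers, with a 2.5-fold higher number from compound 1 to compound 3 (0.40 log units; beyond the scatter). Compound 4 (`CCc1cccc2c(OC)c(-c3occ(C)c3COC(C)=O)ccc12`) carries acetyl in place of methyl on an oxygen on a saturated carbon, acetyl in place of methyl on an oxygen on a saturated carbon. For the measured compounds named here, no measured step makes this exact change. The closest guide is a 2.5-fold higher number from compound 1 to compound 3 (0.40 log units; beyond the scatter), where methoxymethyl replaced ethoxycarbonyl, while an at least 1.0-fold lower number from compound 2 to compound 3 (0.01 log units; that floor lies within the scatter) adds little. Acetoxymethyl restores a carbonyl, so a small move back toward compound 1 is expected, probably within the scatter. The expected change is a 1.6-fold lower number from compound 3 to compound 4 (0.21 log units; within the scatter). For compound 4 the estimated value is 6 ug/mL, within a range of 3 ug/mL to 12 ug/mL.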

Compound 4, concentration for half-maximal effect: 3.5 ug/mL
For compound 4 the middle estimate is 1.7-fold (0.23 log units) above the measured one; the measured number falls inside the stated range.
By their numbers in this assay, from the lowest: compounds 4 and 1 (each within the scatter of the next); then compound 3. At a limit, above all of these: compound 2.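

In this assay, acetyl in place of methyl on this oxygen gives a 2.8-fold lower number from compound 3 to compound 4 (0.44 log units; beyond the scatter), the first change shown that lowers the number beyond the scatter. The acetoxymethyl group also brings the compound level with the ethoxycarbonyl group, with a 1.1-fold lower number from compound 1 to compound 4 (0.05 log units; within the scatter). Compound 2 stands at a limit, so the step of an at least 2.8-fold lower number from compound 2 to compound 4 (0.45 log units; beyond the scatter) is only a floor: the limit of > 10 ug/mL in this assay, at which 1 of the 4 values shown sits.

The compounds shown leave open whether a free hydroxymethyl, an aminomethyl or a longer acyl chain such as propionyl in this place would hold the number of compound 4. They also do not show what lies behind the step.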